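Ethynyl for Ethyl on a Thiourea Cinchona-Type Scaffold

The compounds below may be only part of what the source reports. "The series", "measured", "known", "first", "only" and "open" are said of these compounds alone.

Measured so far:
- compound 1, `C#C[C@H]1CN2CC[C@H]1C[C@H]2[C@@H](Nc1c(Nc2cc(C(F)(F)F)cc(C(F)(F)F)c2)c(=O)c1=O)c1ccnc2ccc(OC)cc12`: 14000 nM
- compound 2, `CC[C@H]1CN2CC[C@H]1C[C@H]2[C@@H](NC(=S)Nc1cc(C(F)(F)F)cc(C(F)(F)F)c1)c1ccnc2ccc(OC)cc12`: 1500 nM
- compound 3, `CC[C@H]1CN2CC[C@H]1C[C@H]2[C@@H](Nc1c(NCc2ccccc2)c(=O)c1=O)c1ccnc2ccc(OC)cc12`: 21000 nM

Of the compounds shown here, three sharing one bridged bicyclic core have been tested in a functional assay on MES-SA/Dx5 cells (Homo sapiens) for inhibition, read by fluorescence, with a stated time of 144 h; a lower number here means a stronger inhibitor, a higher number a weaker inhibitor. In this assay compound 2 gives 1500 nM, the lowest number of the three; compound 1 gives 14000 nM and compound 3 gives 21000 nM, and both gaps to compound 2 lie beyond the usual scatter, so compound 2 is the strongest inhibitor of the set. Compound 2 carries a thiourea linking the core to a bis(trifluoromethyl)phenyl ring, whereas compound 1 and compound 3 carry a squaramide in that position.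

The next compound, compound 4, `C#C[C@H]1CN2CC[C@H]1C[C@H]2[C@@H](NC(=S)Nc1cc(C(F)(F)F)cc(C(F)(F)F)c1)c1ccnc2ccc(OC)cc12`, keeps the thiourea of compound 2 and changes only the substituent on the core: ethynyl in place of ethyl on a saturated ring carbon

Going by the values given here, no pair of measured compounds differs by exactly this change, so its size is not known directly. Compound 1 and compound 3 both carry squaramides and differ in two places, so they do not isolate the ethyl-to-ethynyl swap. A swap of two small two-carbon groups on a saturated ring carbon, away from the thiourea, is expected to move the number little, with no clear direction. Compound 4 is therefore expected to give 1800 nM, within 700 nM to 4500 nM. The expected step of a 1.2-fold higher number from compound 2 to compound 4 (0.08 log units; within the scatter) is estimated to lie within the scatter.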

Compound 4, half-maximal inhibitory concentration: 3900 nM
The estimate for compound 4 lay 2.2-fold (0.34 log units) below the measured number; the measured number falls inside the stated range.
By their numbers in this assay, from the lowest: compound 2; then compound 4; then compounds 1 and 3 (each within the scatter of the next).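

In this assay, replacing ethyl with ethynyl gives a 2.6-fold higher number from compound 2 to compound 4 (0.41 log units; beyond the scatter). Going by these compounds alone, this is the first direct reading of this position, since no earlier pair differed in one place only, and it shows that the saturated ring carbon two ring bonds from the ring nitrogen is not indifferent to its substituent, even though both groups have the same count of heavy atoms and neither has hydrogen-bond donors or acceptors. The step is modest, and nothing measured here explains why the triple bond comes with a higher number.

The compounds shown carry only ethyl and ethynyl at this carbon, so it remains open whether other groups there, such as a longer chain like propyl, a vinyl group or a hydroxymethyl group, would give a number close to that of compound 2 or move further from it. It is also open whether the same swap has a similar size when a squaramide replaces the thiourea, as no pair of squaramide compounds shown differs by this change alone.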